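This account rests on a few compounds, and the source may have more. Where it says the series, first, only, none or still open, it means among the compounds named here.

Working notes on the succinate-ester series.

Of the compounds shown here, three on the shared core have been measured. Compound 1 `CCCCOC(=O)CCC(=O)N1CCN(CCCOc2cc3c(Nc4ccc(F)c(Cl)c4)ncnc3cc2OC)CC1` in a functional assay on A549 cells (Homo sapiens) for cytotoxicity, read by MTT assay, with a stated time of 24 h, tested at 40 uM (on this read-out lower numbers stand for a stronger effect and higher numbers for a weaker effect at the one concentration tested), gives 79.1%. Compound 2 `CCCCCCCOC(=O)CCC(=O)N1CCN(CCCOc2cc3c(Nc4ccc(F)c(Cl)c4)ncnc3cc2OC)CC1` in this assay gives 59.1%. Compound 3 `CCCCCCCCCCCCCCCOC(=O)CCC(=O)N1CCN(CCCOc2cc3c(Nc4ccc(F)c(Cl)c4)ncnc3cc2OC)CC1` in this assay gives 85.5%, the highest of the three numbers; compound 1 lies within the scatter of it, compound 2 beyond.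

The single-point steps are a number 20 percentage points lower from compound 1 to compound 2 (beyond the scatter), a number 6.4 percentage points higher from compound 1 to compound 3 (within the scatter) and a number 26.4 percentage points higher from compound 2 to compound 3 (beyond the scatter). Chain lengthening thus gave a lower number in one step and a higher number in another, with no ordered trend across compounds 1, 2 and 3.

Compound 4 `CCCCCCCCCCCCCCCCOC(=O)CCC(=O)N1CCN(CCCOc2cc3c(Nc4ccc(F)c(Cl)c4)ncnc3cc2OC)CC1` differs from compound 3 by methyl in place of hydrogen on a saturated chain carbon, ten or more bonds along the chain from an oxygen next to a carbonyl group. Among the compounds with values here, all three measured steps concern far larger chain extensions than this one, and the only step close in size, from compound 1 to compound 3, stays within the scatter. A single added methyl on an already long chain is therefore expected to give no step beyond the scatter in this assay, so that a number 2.5 percentage points lower from compound 3 to compound 4 (within the scatter) is expected. Compound 4 is estimated at 83%, with a range from 68% to 96%.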

Compound 4, a percentage reported as activity, at one concentration (the size of the read-out at that concentration, not a potency): 82.6%
For compound 4 the middle estimate is 0.4 percentage points above the measured one; measured number inside the range.
By their numbers in this assay, from the lowest: compound 2; then compounds 1, 4 and 3 (each within the scatter of the next).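

At this far end of the chain, methyl in place of hydrogen changes little in this assay, with a number 2.9 percentage points lower from compound 3 to compound 4 (within the scatter), so the extension here gives no step beyond the scatter. Within the data shown here, the low number of compound 2 now stands against a second long chain, with a number 23.5 percentage points higher from compound 2 to compound 4 (beyond the scatter), while the step from the shorter chain stays small, with a number 3.5 percentage points higher from compound 1 to compound 4 (within the scatter); the series therefore still shows no ordered trend with chain length, and compound 2 remains the one compound apart from the rest. No supporting data bear on why these numbers fall as they do.

Open, as far as these compounds go, is where, at chain lengths between those of compound 2 and compound 3, the number climbs back. Also open, from the compounds shown here alone, is whether a carboxylic acid in place of the ester, or an amine at the far end of the chain, would hold the low number of compound 2.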